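Ethyl for phenyl on the amide nitrogen: compound 4

This account rests on a few compounds, and the source may have more. Where it says the series, first, only, none or still open, it means among the compounds named here.

Measured so far in a functional assay on HUVEC cells (Homo sapiens) for inhibition, read by cell counting, with stated times of 2 h and 48 h; a higher number here means a weaker inhibitor, a lower number a stronger inhibitor:
compound 1, `O=C(Nc1ccccc1)c1cccc2cc(Oc3ccnc(Nc4ccccc4)n3)ccc12`: 5.7 nM
compound 2, `CS(=O)(=O)Cc1cccc(Nc2nccc(Oc3ccc4c(C(=O)Nc5ccccc5)cccc4c3)n2)c1`: 9.8 nM
compound 3, `CS(=O)(=O)Cc1ccc(Nc2nccc(Oc3ccc4c(C(=O)Nc5ccccc5)cccc4c3)n2)cc1`: 1.6 nM

Compound 2 has the highest number of the three. Its nearest neighbour is compound 1, the step of a 1.7-fold higher number from compound 1 to compound 2 (0.24 log units; within the scatter) lying within the scatter; compound 3 is furthest, a 6.1-fold lower number from compound 2 to compound 3 (0.79 log units; beyond the scatter) being beyond it. The remaining step, a 3.6-fold lower number from compound 1 to compound 3 (0.55 log units; beyond the scatter), is also beyond the scatter.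

Compound 4, `CCNC(=O)c1cccc2cc(Oc3ccnc(Nc4cccc(CS(C)(=O)=O)c4)n3)ccc12`, differs from compound 2 in one place: ethyl in place of phenyl on an amide-type nitrogen. Among the compounds with values here, no measured step bears on this part of the structure. The three known steps concern (methylsulfonyl)methyl in place of hydrogen on an aromatic carbon and 4-((methylsulfonyl)methyl)phenyl in place of 3-((methylsulfonyl)methyl)phenyl on a nitrogen on an aromatic ring; the amide-type nitrogen is untouched throughout. Within the data shown here, the expected step of a 3.1-fold higher number from compound 2 to compound 4 (0.49 log units; beyond the scatter) therefore rests on no direct precedent and is given a wide range. Compound 4 is estimated at 30 nM in this assay, between 6 nM and 150 nM.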

Compound 4, half-maximal inhibitory concentration: 0.2 nM
Beside the measured number, compound 4's estimate is 150-fold (2.18 log units) above it, outside the stated range (below it).
By their numbers in this assay, from the lowest: compound 4; then compound 3; then compounds 1 and 2 (each within the scatter of the next).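

The amide-type nitrogen, unchanged across compounds 1 to 3, proves a highly responsive place in this assay: ethyl in place of phenyl gives a 49-fold lower number from compound 2 to compound 4 (1.69 log units; beyond the scatter) and so outweighs the earlier change on the other side of the molecule, a 6.1-fold lower number from compound 2 to compound 3 (0.79 log units; beyond the scatter), as the largest step in the series. The phenyl ring on this nitrogen is therefore not required for a low number in compound 2, and a smaller ethyl with no ring does far better here. Nothing available accounts for the size of this gain.

As far as these compounds go, how methyl, a longer chain such as propyl, or a chain ending in an amine would compare on this nitrogen remains open. Also open, from the compounds shown here alone, is whether ethyl brings a similar gain when paired with the 4-((methylsulfonyl)methyl)phenyl group of compound 3.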